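The compounds below may be only part of what the source reports. "The series", "measured", "known", "first", "only" and "open" are said of these compounds alone.

Working notes on the series.

Compound 1 `CN(C)CCN(CCN(C)C)c1ccc(C(=O)N2CCc3ccc(OS(N)(=O)=O)cc3C2)cc1` and compound 2 `CN(C)CCN(Cc1ccccc1)c1ccc(C(=O)N2CCc3ccc(OS(N)(=O)=O)cc3C2)cc1` share one core and differ only on the chain carbon bound to the nitrogen on the aromatic ring. In an assay on HEK293 cells for inhibition of Steryl-sulfatase (Homo sapiens), tested at 1 uM (on this read-out higher numbers stand for a stronger effect at the one concentration tested and lower numbers for a weaker effect), compound 1 gives 15.9%, the lower of the two numbers measured; in this assay compound 2 gives 57.8%. For the measured compounds named here, the one step measured is a number 41.9 percentage points higher from compound 1 to compound 2 (beyond the scatter), so a change at this nitrogen can move the read-out well beyond the scatter.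

Compound 3 `CN(CCCN1CCCCC1)c1ccc(C(=O)N2CCc3ccc(OS(N)(=O)=O)cc3C2)cc1` is not yet measured. Against compound 1 the change is methyl(3-(piperidin-1-yl)propyl)amino in place of bis(2-(dimethylamino)ethyl)amino on an aromatic carbon. It sits on an aromatic carbon of a six-membered aromatic ring of carbon only, para to a large group, the same position that changed from compound 1 to compound 2. That step is the only one that bears on it, and it was large; the new change again removes one of the two (dimethylamino)ethyl arms, so a rise is expected for compound 3, though smaller than the step to compound 2, since no phenyl enters.

The estimate for compound 3 is 35%, with a range from 10% to 62%. The expected step is a number 19.1 percentage points higher from compound 1 to compound 3 (beyond the scatter).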

Compound 3, a percentage reported as inhibition, at one concentration (the size of the read-out at that concentration, not a potency): 40.7%
Beside the measured number, compound 3's estimate is 5.7 percentage points below it, within the range that was stated.
By their numbers in this assay, from the lowest: compound 1; then compound 3; then compound 2.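

The change at this aromatic carbon shows that a rise in the read-out does not need the phenyl of compound 2: in this assay, methyl(3-(piperidin-1-yl)propyl)amino in place of bis(2-(dimethylamino)ethyl)amino gives a number 24.8 percentage points higher from compound 1 to compound 3 (beyond the scatter). The heavy-atom count is the same in the leaving and entering groups, so this step comes with no change in that count, while the entering group brings a six-membered non-aromatic ring and one nitrogen fewer. No measurement at hand bears on why the read-out moves at this position.

The compounds shown leave open which part of the entering group goes with the step, as the arm, the ring and the methyl all differ from compound 1 at once. A dimethylamino group on the same propyl chain, a piperidine ring on a shorter ethyl chain, or a morpholine ring in place of the piperidine ring would each change only one of these parts and would separate the ring from the chain.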